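Methyl to hydrogen on an aromatic carbon: cytotoxicity notes

This account rests on a few compounds, and the source may have more. Where it says the series, first, only, none or still open, it means among the compounds named here.

The series holds compound 1 `Cc1ccc(/N=N/N(C)c2ccccc2)cc1`, compound 3 `CN(/N=N/c1ccccc1)c1ccccc1`, compound 2 `Cc1ccc(/N=N/c2ccc(NCCCN(C)C)cc2)cc1` and the still unmeasured compound 4 `CN(C)CCCNc1ccc(/N=N/c2ccccc2)cc1`. In an ADME assay on MDBK cells (Bos taurus) for cytotoxicity, read by MTT assay, with a stated time of 96 h (on this read-out lower numbers stand for higher toxicity in this test and higher numbers for lower toxicity in this test), compound 1 gives > 100000 nM, which is a limit of the assay and not a number. In this assay compound 3 likewise gives > 100000 nM, again a limit. The change from compound 1 to compound 3 is hydrogen in place of methyl on an aromatic carbon. The step this made, a step that the two limits leave unreadable from compound 1 to compound 3, cannot be read because of the limit of > 100000 nM in this assay, at which 3 of the 3 values shown sit.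

In this assay compound 2 gives > 100000 nM, also a limit. How the core of compound 2 differs from the core of compound 1 is not broken down here. The change from compound 2 to compound 4 is hydrogen in place of methyl on an aromatic carbon; its place reads word for word as for compound 1 to compound 3, so it is the same change, and it occurs twice among the compounds shown.

For compound 4 the step from compound 2 is expected to be a step that the limit leaves unreadable from compound 2 to compound 4, set beside a step that the two limits leave unreadable from compound 1 to compound 3; the expectation rests on the three measured compounds all sitting at the limit of > 100000 nM in this assay, at which 3 of the 3 values shown sit, so that the earlier step gives no size to carry over and no measured value points away from the limit. Compound 4 is therefore estimated at 150000 nM in this assay, with a range from 70000 nM to 500000 nM, and it is expected most likely to be reported only as a limit again.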

Compound 4, half-maximal cytotoxic concentration: 58000 nM
Compound 4: the middle estimate sits 2.6-fold (0.41 log units) above what was measured, outside the stated range (below it).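

Hydrogen in place of methyl on an aromatic carbon, taken to the second core, makes in this assay an at least 1.7-fold lower number from compound 2 to compound 4 (0.23 log units; that floor lies within the scatter). That figure is only a floor and does not by itself separate the step from the scatter of repeated measurements, although the true gap may be larger, so the change is not shown to carry a fixed size or a firm direction from one core to another. The same change on the first core, from compound 1 to compound 3, cannot be read, and no two sizes can be set side by side because both of its ends are limits, as is the starting value of the readable step: the limit of > 100000 nM in this assay, at which 3 of the 4 values shown sit.

As far as these compounds go, it stays open whether the number for compound 4 reflects the change to phenyl alone or also depends on the core, and whether the step would be readable on a core whose values lie clear of the limit. Also open, from the compounds shown here alone, is how this assay would read with a carboxylic acid or a longer chain in place of the side chain of compound 4, or with fluorine in place of the methyl of compound 2.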